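The source may report more compounds than this note shows. Statements on the series, on what has been measured and on what is new or still open speak of the compounds shown alone.

Compounds measured so far:

- compound 1, `c1cncc(-c2ccccc2OCC2=NCCN2)c1`: 158 nM
- compound 2, `c1coc(-c2ccccc2OCC2=NCCN2)c1`: < 100000 nM
- compound 3, `c1csc(-c2ccccc2OCC2=NCCN2)c1`: 15.9 nM

Three compounds share one core and differ only in the aromatic ring attached to it. In a functional assay for activation of Alpha-1D adrenergic receptor (Homo sapiens), read by calcium flux (on this read-out lower numbers stand for an effect already at smaller amounts and higher numbers for an effect only at larger amounts of compound), compound 1 gives 158 nM. For compound 2 this assay reports only a limit, < 100000 nM, and not a number. Compound 3 gives 15.9 nM in this assay, the lowest of the two numbers available; the step of a 9.9-fold lower number from compound 1 to compound 3 (1.00 log units; beyond the scatter) lies beyond the scatter, so of the two numbered compounds compound 3 is the more potent one. The steps from compound 1 to compound 2 and from compound 2 to compound 3 cannot be sized, because of the limit of < 100000 nM in this assay, at which 1 of the 3 values shown sits.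

Compound 4, `c1ccc(-c2ccsc2)c(OCC2=NCCN2)c1`, is not yet measured. It differs from compound 3 by thiophen-3-yl in place of thiophen-2-yl on an aromatic carbon. Going by the values given here, none of the measured steps swaps one thiophene isomer for another, so there is no direct guide. Compound 4 is therefore expected to stay near compound 3, perhaps with a slightly higher number, a step of about a 2.5-fold higher number from compound 3 to compound 4 (0.40 log units; beyond the scatter) in this assay. The estimate for compound 4 is 40 nM, expected to fall between 10 nM and 160 nM.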

Compound 4, half-maximal effective concentration: 12.6 nM
Beside the measured number, compound 4's estimate is 3.2-fold (0.50 log units) above it; low and high end bracket the measured number.
By their numbers in this assay, from the lowest: compounds 4 and 3 (each within the scatter of the next); then compound 1.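

Thiophen-3-yl in place of thiophen-2-yl gives a 1.3-fold lower number from compound 3 to compound 4 (0.10 log units; within the scatter) in this assay, so on this aromatic carbon the two thiophene isomers cannot be told apart in this read-out. Thiophen-3-yl in place of pyridin-3-yl brings a 13-fold lower number from compound 1 to compound 4 (1.10 log units; beyond the scatter), which shows that the lower number seen with thiophen-2-yl is not tied to one isomer. The step from compound 2 to compound 4 cannot be read, and the same holds for the other steps involving compound 2: the limit of < 100000 nM in this assay, at which 1 of the 4 values shown sits.

Going by these compounds, it remains open whether furan-3-yl would behave like furan-2-yl or like the two thiophenes. Also open, on these data alone, is how a plain phenyl ring would compare here, and what a methyl group or a chlorine atom on the thiophene ring would do.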